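Adding a methoxy to the benzoyl ring of compound 3

A few compounds are considered here, and "the series" means these few. Any claim that something is new, unique, unknown or untested is made for them only; others in the source may bear on it.

- compound 1 `COc1ccc(/C=C/c2cc(OC)cc(OC)c2/C=C/C(=O)c2cccc(Cl)c2)cc1`: 5.6 ug/mL
- compound 2 `CCOc1ccc(C(=O)/C=C/c2c(/C=C/c3ccc(OC)cc3)cc(OC)cc2OC)cc1`: 7.5 ug/mL
- compound 3 `COc1ccc(/C=C/c2cc(OC)cc(OC)c2/C=C/C(=O)c2ccccc2)cc1`: 3.9 ug/mL

In a functional assay on A549 cells (Homo sapiens) for antiproliferative activity, read by MTT assay, with a stated time of 48 h (a lower number here means a stronger inhibitor, a higher number a weaker inhibitor), compound 3 gives 3.9 ug/mL, but this does not set it apart from the other two compounds, as its steps to both lie within the scatter. Compound 4 `COc1ccc(/C=C/c2cc(OC)cc(OC)c2/C=C/C(=O)c2ccc(OC)cc2)cc1` follows from compound 3 with methoxy in place of hydrogen on an aromatic carbon, para to a large group: methoxy in place of hydrogen on an aromatic carbon. The closest measured change is the removal of an ethoxy, a 1.9-fold lower number from compound 2 to compound 3 (0.28 log units; within the scatter). The removal of a chloro, a 1.4-fold lower number from compound 1 to compound 3 (0.16 log units; within the scatter), also bears on it, and a 1.3-fold higher number from compound 1 to compound 2 (0.13 log units; within the scatter) shows that exchanging these two substituents did little more. None of these steps leaves the scatter, so no step beyond the scatter is expected in this assay, though a slightly higher number would fit compound 2 at 7.5 ug/mL. The expected step is a 1.4-fold higher number from compound 3 to compound 4 (0.13 log units; within the scatter). For compound 4 the estimated value is 5.3 ug/mL, with an expected range from 2.9 ug/mL to 9.5 ug/mL.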

Compound 4, half-maximal inhibitory concentration: 4.5 ug/mL
Compound 4: middle estimate off by 1.2-fold (0.07 log units), on the high side, within the range that was stated.
By their numbers in this assay, from the lowest: compounds 3, 4, 1 and 2 (each within the scatter of the next).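

In this assay, methoxy on the benzoyl ring, para to a large group, stays within the scatter of the unsubstituted ring (a 1.2-fold higher number from compound 3 to compound 4 (0.06 log units; within the scatter)), so this change does not set compound 4 apart from compound 3. Compound 4 also adds a direct comparison of methoxy with ethoxy at this place (a 1.7-fold lower number from compound 2 to compound 4 (0.22 log units; within the scatter)), and its 4-methoxyphenyl can be set against the 3-chlorophenyl of compound 1 (a 1.2-fold lower number from compound 1 to compound 4 (0.09 log units; within the scatter)); both steps lie within the scatter, so the four compounds cannot be told apart here. No measurement at hand offers an explanation for this flat result.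

From the compounds shown here alone, whether an amine or a carboxylic acid at this place would give a step beyond the scatter remains open. So does the effect of a chain longer than ethoxy.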